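This account rests on a few compounds, and the source may have more. Where it says the series, first, only, none or still open, it means among the compounds named here.

Compound 1 `COc1ccc(/C=C/S(=O)(=O)Nc2ccc(OC)cc2)cc1` — 5000 nM
Compound 2 `COc1cc(OC)c(/C=C/S(=O)(=O)Nc2ccc(OC)c(OP(=O)(O)O)c2)c(OC)c1` — 40 nM

Of the compounds shown here, two have been measured in a functional assay on DU-145 cells (Homo sapiens) for cytotoxicity, read by trypan blue exclusion, with a stated time of 96 h; a higher number here means a weaker inhibitor, a lower number a stronger inhibitor. Compound 1 gives 5000 nM there, while compound 2 gives 40 nM, the lower of the two numbers; the gap between them lies well beyond the usual scatter, so compound 2 is the stronger inhibitor of the pair on what is shown. Going by the values given here, the two differ in several places at once, so no single step between them can be read from the data.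

Compound 3 `COc1cc(OC)c(/C=C/S(=O)(=O)Nc2ccc(OC)c(NC(C)(C)C(=O)O)c2)c(OC)c1` has not yet been measured. It differs from compound 2 in one place: a group of 7 heavy atoms (4 carbon, 1 nitrogen, 2 oxygen; no ring) in place of a group of 5 heavy atoms (4 oxygen, 1 phosphorus; no ring), on an aromatic carbon. Among the compounds with values here, no measured pair in this set isolates a change of this kind, so the size of the step in this assay can only be guessed. The expectation is a moderate rise in the number, that is, a somewhat weaker inhibitor than compound 2, with a wide range. For compound 3 the estimate in this assay is 150 nM, with a range from 20 nM to 1500 nM. This corresponds to an expected step of a 3.8-fold higher number from compound 2 to compound 3 (0.57 log units; beyond the scatter).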

Compound 3, half-maximal inhibitory concentration: 70 nM
The estimate for compound 3 lay 2.1-fold (0.33 log units) above the measured number; the measured number falls inside the stated range.
By their numbers in this assay, from the lowest: compounds 2 and 3 (each within the scatter of the next); then compound 1.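

The result shows that this aromatic carbon, ortho to a methoxy group, accepts two quite different groups with no reading of a difference between them. Replacing the phosphorus-bearing group of compound 2 with the (1-carboxy-1-methylethyl)amino group of compound 3 gives a 1.8-fold higher number from compound 2 to compound 3 (0.24 log units; within the scatter) in this assay, so phosphorus is not required at this position for a number in this range, at least with this replacement. The two groups share the counted features, with the same numbers of hydrogen-bond donors and acceptors and no net charge, but no measurement here links those counts to the result or explains why the two numbers lie so close.

The compounds shown leave open how a simple amine, a hydroxyl group or a bare hydrogen at this carbon would compare with these two groups, and therefore whether either group contributes to the number at all. They also leave open whether the carboxylic acid or the two methyl groups of the (1-carboxy-1-methylethyl)amino group matter, and what a methyl ester or a longer chain in its place would give.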